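Compound 4: benzyl in place of 3-bromophenyl on the nitrogen

The source may report more compounds than this note shows. Statements on the series, on what has been measured and on what is new or still open speak of the compounds shown alone.

Compound 3 `S=C(N/N=C/c1ccc2ccccc2n1)Nc1cccc(Br)c1` gives 70000 nM in a functional assay on HeLa cells (Homo sapiens) for antiproliferative activity, read by sulforhodamine B assay, with a stated time of 72 h (a lower number here means a stronger inhibitor, a higher number a weaker inhibitor), the second highest of the three numbers: compound 1 `COc1cccc(NC(=S)N/N=C/c2ccc3ccccc3n2)c1` at 74500 nM lies within the scatter of it, while the step of a 3.5-fold higher number from compound 2 to compound 3 (0.54 log units; beyond the scatter) separates it from compound 2 `N#Cc1ccc(NC(=S)N/N=C/c2ccc3ccccc3n2)cc1`, which gives 20000 nM. Compound 4 `S=C(NCc1ccccc1)N/N=C/c1ccc2ccccc2n1` carries the change (benzyl in place of 3-bromophenyl on an amide-type nitrogen). Within the data shown here, the steps that bear on the group on the amide-type nitrogen are a 3.7-fold lower number from compound 1 to compound 2 (0.57 log units; beyond the scatter) and a 1.1-fold lower number from compound 1 to compound 3 (0.03 log units; within the scatter); each exchanges one aryl group for another, and no measured step involves benzyl, so the precedent is indirect. Because those steps, a 3.7-fold lower number from compound 1 to compound 2 (0.57 log units; beyond the scatter) and a 1.1-fold lower number from compound 1 to compound 3 (0.03 log units; within the scatter), were modest at most, compound 4 is expected to stay near that level, with a step of a 1.2-fold lower number from compound 3 to compound 4 (0.07 log units; within the scatter) that need not exceed the scatter. The estimate for compound 4 is 60000 nM, within 15000 nM to 150000 nM.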

Compound 4, half-maximal inhibitory concentration: 62800 nM
The estimate for compound 4 lay 1.0-fold (0.02 log units) below the measured number; low and high end bracket the measured number.
By their numbers in this assay, from the lowest: compound 2; then compounds 4, 3 and 1 (each within the scatter of the next).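

Benzyl is the first group on the amide-type nitrogen in this assay that is not a directly attached aryl ring, yet a 1.1-fold lower number from compound 3 to compound 4 (0.05 log units; within the scatter) and a 1.2-fold lower number from compound 1 to compound 4 (0.07 log units; within the scatter) leave compound 4 level with both compound 3 and compound 1. The exchange for 4-cyanophenyl gives a 3.1-fold higher number from compound 2 to compound 4 (0.50 log units; beyond the scatter) and so, among these four groups, 4-cyanophenyl alone stands apart, with compound 2 giving the lowest number. Open, on these data alone, is whether phenethyl, a longer chain, or an aminomethyl or carboxylic acid group on the benzyl ring would depart from this level. No measurement shown gives a reason for these results.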